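Bromo to iodo at a chain end on two cores

The source may hold more compounds than are shown below. What is called first, only, known or untested is meant among the compounds shown, and "the series" means these compounds.

In a functional assay on HEL cells (Homo sapiens) for cytotoxicity (a higher number here means that more compound is tolerated, a lower number that less compound is tolerated), compound 1 `O=c1[nH]c(=O)n([C@H]2C[C@H](O)[C@@H](CO)O2)cc1C#CCCCCCCCCCBr` gives 97000 nM. Compound 2 `O=c1[nH]c(=O)n([C@H]2C[C@H](O)[C@@H](CO)O2)cc1C#CCCCCCCCCCI` carries iodo in place of bromo on a saturated chain carbon, nine bonds along the chain from a triple-bonded carbon and gives 68000 nM in this assay; the measured step is a 1.4-fold lower number from compound 1 to compound 2 (0.15 log units; within the scatter). Compound 3 `O=c1nc2oc(CCCCCCCCCBr)cc2cn1[C@H]1C[C@H](O)[C@@H](CO)O1` has the same atoms as compound 1 joined differently, and the difference between the two cores is not broken down here. For compound 3 this assay reports only a limit, > 50000 nM; this is the limit of > 50000 nM in this assay, at which 1 of the 3 values shown sits. Compound 4 `O=c1nc2oc(CCCCCCCCCI)cc2cn1[C@H]1C[C@H](O)[C@@H](CO)O1` differs from compound 3 by iodo in place of bromo on a saturated chain carbon, nine bonds along the chain from an aromatic carbon. Here the place is a saturated chain carbon nine bonds along the chain from an aromatic carbon rather than from a triple-bonded carbon, so it is the same kind of change, not the same change. In this assay the expected step that the limit leaves unreadable from compound 3 to compound 4 is set beside the earlier step because a 1.4-fold lower number from compound 1 to compound 2 (0.15 log units; within the scatter) stayed within the scatter. Compound 4 is therefore estimated at 60000 nM, expected between 30000 nM and 130000 nM, and it may again be reported only as a limit.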

Compound 4, half-maximal cytotoxic concentration: > 200000 nM
Compound 4: no number, only a limit; the forecaster's own chance of this, stated with the estimate: 60%; middle value at least 3.3-fold (0.52 log units) away from the limit.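

In this assay, compound 3 and compound 4 are both reported only as limits, and the step between them cannot be read. The compounds shown leave open whether iodo in place of bromo changes the tolerated concentration on the core of compound 3 at all.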